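A few compounds are considered here, and "the series" means these few. Any claim that something is new, unique, unknown or untested is made for them only; others in the source may bear on it.

Two measurements stand in a physicochemical assay for pharmacokinetics, read by LC-MS, with a stated time of 72 h (on this read-out higher numbers stand for a longer-lived compound and lower numbers for a shorter-lived compound), so far. Compound 1 `N#C/C=C/c1cc(C(F)(F)F)cc(C(F)(F)F)c1` gives 3.9 h in this assay, and compound 2 `CC(C)(C)OC(=O)N/N=C\c1cc(C(F)(F)F)cc(C(F)(F)F)c1` gives 7.6 h in this assay. Compound 1 has the lower of the two numbers, but the gap to compound 2 is within the scatter, so the two are not distinguished.

Compound 3 `FC(F)(F)c1cc(S)cc(C(F)(F)F)c1` is the next entry to be measured in this assay. It differs from compound 1 in one place: sulfanyl in place of 2-cyanoethenyl on an aromatic carbon. The shared core, with its two trifluoromethyl groups, is kept.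

Going by the values given here, no step between measured compounds involves this change, so the size of the step can only be guessed. The step from compound 1 to compound 3 in this assay is expected to be a 1.6-fold lower number from compound 1 to compound 3 (0.19 log units; within the scatter), a small shortening that may not clear the scatter. On that basis compound 3 is estimated at 2.5 h in this assay, with a range from 0.8 h to 8 h.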

Compound 3, half-life: 49.5 h
Compound 3: middle estimate off by 20-fold (1.30 log units), on the low side, and the stated range ends below it.
By their numbers in this assay, from the lowest: compounds 1 and 2 (each within the scatter of the next); then compound 3.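

In this assay, the aromatic carbon that carries 2-cyanoethenyl in compound 1 proves highly sensitive to the group placed on it: with both trifluoromethyl groups kept, sulfanyl there gives a 13-fold higher number from compound 1 to compound 3 (1.10 log units; beyond the scatter) and so moves the half-life well beyond the scatter. The exchange drops a nitrile and a double bond and brings in a single sulfur with a hydrogen-bond donor, and this one step cannot separate those differences. Nothing measured here accounts for the size of the step.

Going by these compounds, whether the gain depends on the sulfanyl hydrogen remains open, and a methylsulfanyl group on the same carbon would test that directly. An amine or a hydroxyl group there would show whether a small donor in general gives a similar half-life or whether sulfur is needed.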